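Aryl swap on the ring amine nitrogen: compound 3

The source may report more compounds than this note shows. Statements on the series, on what has been measured and on what is new or still open speak of the compounds shown alone.

In an assay on CHO cells for displacement of a labelled ligand from adenosine receptor A3 (Homo sapiens), read by scintillation counting, with a stated time of 120 min, tested at 10 uM (on this read-out higher numbers stand for more inhibition at the one concentration tested (going by the name of the read-out) and lower numbers for less inhibition), compound 2 `Nc1scc(CN2CCN(c3cc(F)cc(F)c3)CC2)c1C(=O)c1ccc(Cl)cc1` gives 2%. Compound 1 `COc1ccc(N2CCN(Cc3csc(N)c3C(=O)c3ccc(Cl)cc3)CC2)cc1` gives 0%, and the two numbers lie within the usual scatter of each other. Compound 3 `Nc1scc(CN2CCN(c3ccccc3Cl)CC2)c1C(=O)c1ccc(Cl)cc1` differs from compound 2 by 2-chlorophenyl in place of 3,5-difluorophenyl on an amine nitrogen in a ring. For the measured compounds named here, the only step that bears on this change is the earlier swap of the aryl group on the same nitrogen, a number 2 percentage points higher from compound 1 to compound 2 (within the scatter). An expected step of a number 1 percentage points higher from compound 2 to compound 3 (within the scatter) therefore lies within the scatter. Compound 3 is estimated at 3%, between -8% and 16%.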

Compound 3, a percentage reported as inhibition, at one concentration (the size of the read-out at that concentration, not a potency): 0%
Compound 3: the middle estimate sits 3 percentage points above what was measured, within the range that was stated.
By their numbers in this assay, from the lowest: compounds 1, 3 and 2 (each within the scatter of the next).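

Placing 2-chlorophenyl on this amine nitrogen in a ring gives a number 2 percentage points lower from compound 2 to compound 3 (within the scatter) and no change at the digits printed from compound 1 to compound 3 (within the scatter) in this assay. For the compounds shown here, a chlorine-bearing phenyl ring thus joins the methoxy-bearing and fluorine-bearing ones, and no step among the three compounds leaves the scatter. No measurement at hand accounts for this result. Going by these compounds, what remains open is whether any group on this nitrogen can move the number beyond the scatter, for instance a benzyl or cyclohexyl group, or a phenyl ring carrying a carboxylic acid.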